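Bromo on compound 1: expected step in cytotoxicity

A few compounds are considered here, and "the series" means these few. Any claim that something is new, unique, unknown or untested is made for them only; others in the source may bear on it.

Of the compounds shown here, two have numbers so far. In a functional assay on HEL cells (Homo sapiens) for cytotoxicity (a higher number here means a weaker inhibitor, a lower number a stronger inhibitor), compound 1 (`O=C1O/C(=C\Cn2ccc(=O)[nH]c2=O)C(OCc2ccccc2)=C1OCc1ccccc1`) gives 5000 nM as its half-maximal inhibitory concentration, and compound 2 (`O=C1O/C(=C\Cn2cnc3c(-n4cccc4)ncnc32)C(OCc2ccccc2)=C1OCc1ccccc1`) gives 4000 nM in the same read-out. These two values lie within the scatter of each other, so compound 1 stands level with compound 2 on the numbers available. For the measured compounds named here, no pair of measured compounds differs in one place only, so the size of a single change has not yet been seen directly.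

Compound 3 (`O=C1O/C(=C\Cn2cc(Br)c(=O)[nH]c2=O)C(OCc2ccccc2)=C1OCc1ccccc1`) is still unmeasured. It differs from compound 1 by one change: bromo in place of hydrogen on an aromatic carbon. The close values of compound 1 at 5000 nM and compound 2 at 4000 nM give no ground for expecting a large move. In this assay no step beyond the scatter is expected, in either direction. The expected 1.3-fold lower number from compound 1 to compound 3 (0.10 log units; within the scatter) is therefore small. For compound 3 the estimated value is 4000 nM with an expected range from 1500 nM to 12000 nM in this read-out.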

Compound 3, half-maximal inhibitory concentration: 3000 nM
Compound 3: the middle estimate sits 1.3-fold (0.12 log units) above what was measured; measured number inside the range.
By their numbers in this assay, from the lowest: compounds 3, 2 and 1 (each within the scatter of the next).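

In this assay, for the compounds shown here, bromo in place of hydrogen on an aromatic carbon of the six-membered aromatic ring with 2 nitrogen gives a 1.7-fold lower number from compound 1 to compound 3 (0.22 log units; within the scatter) and provides the first direct reading of a single change. Until now, the comparison rested on two compounds differing in more than one place, so the size of a change at any one position could not be read. At this position, two atoms from the ring nitrogen, the entry of one bromine heavy atom stays within the scatter, so this step gives no firm direction for the read-out, and no measurement bears on why the step has this size.

The compounds shown leave open whether a different group on this same aromatic carbon, such as an amine, a carboxylic acid or a longer chain, would produce a step beyond the scatter. They also leave open whether bromo in place of hydrogen would give a similar step on the core of compound 2, since a single pair cannot show how far this step carries to another core.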